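Chloro in Place of Methoxy: Expected Permeability

The source may hold more compounds than are shown below. What is called first, only, known or untested is meant among the compounds shown, and "the series" means these compounds.

Compound 3 `COc1cccc2c(=O)c(Cc3ccccc3)c(C)[nH]c12` gives 164 10^-6 cm/s in an ADME assay for permeability, using PAMPA, at pH 4 (on this read-out lower numbers stand for lower permeability and higher numbers for higher permeability), the second highest of three numbers. Compound 2 `Cc1[nH]c2ccccc2c(=O)c1Cc1ccccc1` gives 110 10^-6 cm/s in this assay, and compound 1 `CCCCCCCc1c(C)nc2cc(OC)ccc2c1O` gives 1020 10^-6 cm/s; compound 3 sits within the scatter of compound 2 and well below compound 1. Within the data shown here, the only measured step, a 1.5-fold higher number from compound 2 to compound 3 (0.17 log units; within the scatter), shows that putting methoxy onto the shared core changed little. Compound 4 `Cc1[nH]c2c(Cl)cccc2c(=O)c1Cc1ccccc1` carries chloro in place of methoxy on an aromatic carbon. Among the measured compounds shown here, no measured pair shows chloro in place of methoxy, so the expectation rests on the single small step already seen, and the estimated step of a 1.1-fold higher number from compound 3 to compound 4 (0.04 log units; within the scatter) is expected to remain within the scatter. Compound 4 is therefore expected to give 180 10^-6 cm/s in this assay, with a range from 90 10^-6 cm/s to 360 10^-6 cm/s.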

Compound 4, apparent permeability: 430 10^-6 cm/s
Beside the measured number, compound 4's estimate is 2.4-fold (0.38 log units) below it, and the stated range ends below it.
By their numbers in this assay, from the lowest: compounds 2 and 3 (each within the scatter of the next); then compound 4; then compound 1.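

In this assay the group on this aromatic carbon does register: chloro gives a 3.9-fold higher number from compound 2 to compound 4 (0.59 log units; beyond the scatter) in place of hydrogen and a 2.6-fold higher number from compound 3 to compound 4 (0.42 log units; beyond the scatter) in place of methoxy. The earlier compounds shown here showed only a methoxy step within the scatter, so they gave no sign that this position could separate two groups. Nothing measured here explains why chloro stands apart from hydrogen and methoxy. As far as these compounds go, whether an amine or a carboxylic acid on this same carbon would stay with hydrogen and methoxy or move with chloro remains open. So does whether chloro elsewhere on the shared core would give a similar step.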